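Aryl for Aminomethyl on the Triazole Amide Core

The source may hold more compounds than are shown below. What is called first, only, known or untested is meant among the compounds shown, and "the series" means these compounds.

Compound 1 `CC(C)(C)OC(=O)NCc1cn(CC(=O)NCc2ccccc2)nn1` in an ADME assay on cells (spleen, Mus musculus, strain C57BL/6) for inhibition, read by flow cytometry and propidium iodide staining, with a stated time of 24 h, at 37 degrees C (a lower number here means that less compound is needed, a higher number that more compound is needed for the effect), gives > 2000 uM, which is a limit of the assay and not a number.
Compound 2 `NCc1cn(CC(=O)NCc2ccccc2)nn1` gives > 2000 uM, again a limit of the assay.
Compound 3 `O=C(Cn1cc(-c2ccc([N+](=O)[O-])cc2)nn1)NCc1ccccc1` gives 800 uM.

Compound 2 stands at the limit of this assay, where two of the three values shown sit (the limit of > 2000 uM in this assay, at which 2 of the 3 values shown sit). Going by the values given here, the only step measured within the set, a step that the two limits leave unreadable from compound 1 to compound 2, runs between two such limits and offers no readable size. Compound 4 `COc1cccc(-c2cn(CC(=O)NCc3ccccc3)nn2)c1` differs from compound 2 in one place: 3-methoxyphenyl in place of aminomethyl on an aromatic carbon. Among the compounds with values here, no measured step covers this change directly. The closest point of comparison is compound 3, which carries a nitrophenyl on the same aromatic carbon of the shared core and gives 800 uM, a number rather than a limit. Compound 4, with an aryl group at that position, is expected to behave more like compound 3 than like compound 2, though a limit cannot be ruled out. Compound 4 is therefore expected to show an at least 2.0-fold lower number from compound 2 to compound 4 (0.30 log units; that floor lies within the scatter). The estimate for compound 4 is 1000 uM, with a range from 400 uM to 2000 uM.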

Compound 4, concentration for half-maximal effect: 840 uM
The estimate for compound 4 lay 1.2-fold (0.08 log units) above the measured number, and the stated range covers the measured number.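

Going by these compounds alone, at this aromatic carbon of the shared core, 3-methoxyphenyl in place of aminomethyl gives the first readable step in this assay, an at least 2.3-fold lower number from compound 2 to compound 4 (0.37 log units; beyond the scatter). Compound 4 gives 840 uM and compound 3, with a nitrophenyl on the same carbon, gives 800 uM, so two different aryl groups at this place both yield a number rather than a limit. The step marks a floor and not a full size, because the value of compound 2 is a limit of the assay: the limit of > 2000 uM in this assay, at which 2 of the 4 values shown sit.

Going by these compounds, whether the step follows from the arrival of the aromatic ring or from the departure of the aminomethyl remains open. An unsubstituted phenyl, or a longer aminoalkyl chain, at this carbon would separate the two, and the methoxy group's own part in the value of compound 4 is also unresolved.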